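Methoxy in place of fluoro on the phenoxymethyl arm

The source may report more compounds than this note shows. Statements on the series, on what has been measured and on what is new or still open speak of the compounds shown alone.

Of the compounds shown here, three have so far been measured in an assay on isolated protein for inhibition of Intestinal-type alkaline phosphatase (Bos taurus), with stated times of 10 min and 30 min; a lower number here means a stronger inhibitor, a higher number a weaker inhibitor. Compound 1 `Fc1ccc(-c2nn3c(-c4ccncc4)nnc3s2)cc1Cl` gives 2010 nM, compound 2 `Fc1ccc(OCc2nn3c(-c4ccncc4)nnc3s2)cc1` gives 2590 nM, and compound 3 `c1ccc2c(C3=Nn4c(nnc4-c4ccncc4)SC3)cccc2c1` gives 4450 nM. Compound 2 holds the second highest of the three numbers, yet its gap to compound 1 and its gap to compound 3 both fall within the scatter of this assay, so the three cannot be separated. Compound 4 `COc1ccc(OCc2nn3c(-c4ccncc4)nnc3s2)cc1` has not yet been measured in this assay. It differs from compound 2 by methoxy in place of fluoro on an aromatic carbon. Within the data shown here, no measured pair shows this change, so no direction can be read from the data. The step from compound 2 to compound 4 in this assay is expected to be a 1.0-fold lower number from compound 2 to compound 4 (0.02 log units; within the scatter), not clearly beyond the scatter. Compound 4 is therefore estimated at 2500 nM, with a range from 900 nM to 7000 nM.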

Compound 4, half-maximal inhibitory concentration: 3720 nM
Beside the measured number, compound 4's estimate is 1.5-fold (0.17 log units) below it; low and high end bracket the measured number.
By their numbers in this assay, from the lowest: compounds 1, 2, 4 and 3 (each within the scatter of the next, the first and the last beyond it).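

In this assay, among these compounds, the change from 4-fluorophenyl to 4-methoxyphenyl gives a 1.4-fold higher number from compound 2 to compound 4 (0.16 log units; within the scatter) as the first measured pair at this position. Methoxy brings one more heavy atom and a hydrogen-bond acceptor that fluoro lacks, yet this pair shows no change that can be separated from the scatter. Nothing available explains this result. From the compounds shown here alone, whether an amine, a carboxylic acid or a longer chain on this aromatic carbon would move the number beyond the scatter stays open. So does whether methoxy in place of fluoro would read the same on another core.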